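The source may report more compounds than this note shows. Statements on the series, on what has been measured and on what is new or still open speak of the compounds shown alone.

Compound 1 `CCCS(=O)(=O)Nc1ccc(F)c(C(=O)c2n[nH]c3ncc(-c4cccc(N)c4)cc23)c1F` and compound 2 `CCCS(=O)(=O)Nc1ccc(F)c(C(=O)c2n[nH]c3ncc(-c4cccc([N+](=O)[O-])c4)cc23)c1F` share one core. In an assay for binding affinity to dual specificity mitogen-activated protein kinase kinase 4 (Homo sapiens), read by KINOMEscan, tested at 100 nM (a lower number here means a stronger effect, a higher number a weaker effect of the compound at the concentration tested), compound 1 gives 1.6% and compound 2 gives 15%, the highest of the two numbers shown. Among the compounds with values here, the only measured step, a number 13.4 percentage points higher from compound 1 to compound 2 (beyond the scatter), shows that exchanging the group in this part of the molecule shifts the read-out modestly. Compound 3 `CCCS(=O)(=O)Nc1ccc(F)c(C(=O)c2n[nH]c3ncc(-c4ccc(C(N)=O)cc4)cc23)c1F` differs from compound 2 by 4-carbamoylphenyl in place of 3-nitrophenyl on an aromatic carbon. Within the data shown here, no measured step matches this exact change; the amino-to-nitro step is the nearest guide and was modest. Compound 3 is therefore expected to show a number 10 percentage points lower from compound 2 to compound 3 (within the scatter), a drop, with an estimated 5% and a range from 1% to 20%.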

Compound 3, a percentage reported as activity, at one concentration (the size of the read-out at that concentration, not a potency): 0.15%
Estimate against measurement, compound 3: 4.9 percentage points above; measured number below the stated range.
By their numbers in this assay, from the lowest: compounds 3 and 1 (each within the scatter of the next); then compound 2.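

In this assay, the new aryl group at this position gives a number 14.9 percentage points lower from compound 2 to compound 3 (beyond the scatter), so the 3-nitrophenyl is not the only replacement for which the read-out moves beyond the scatter. The second comparison gives a number 1.5 percentage points lower from compound 1 to compound 3 (within the scatter), which shows that this position accepts 4-carbamoylphenyl and 3-aminophenyl with no separable difference, although the group and its place on the phenyl ring both change. Nothing shown gives a reason for these results. Still open, from the compounds shown here alone, is whether a carboxylic acid in place of the carbamoyl would read like compound 3 or compound 2, and whether unsubstituted phenyl would match either.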